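This account rests on a few compounds, and the source may have more. Where it says the series, first, only, none or still open, it means among the compounds named here.

Measured compounds in a functional assay on CHOK cells for antagonist activity at growth hormone secretagogue receptor type 1 (Homo sapiens), read by calcium flux; a higher number here means a weaker inhibitor, a lower number a stronger inhibitor:

- compound 1, `CCc1nc(N)nc(N)c1-c1ccc(NCc2cc(F)c(S(C)(=O)=O)c(F)c2)cc1`: 45 nM
- compound 2, `CCc1nc(N)nc(N)c1-c1ccc(NCc2ccnc(Cl)c2)cc1`: 220 nM
- compound 3, `N#Cc1ccc(CNc2ccc(-c3c(N)nc(N)nc3COCc3ccccc3)cc2)cc1`: 19 nM

Compound 3 stands at the lowest number of the three. Its nearest neighbour is compound 1, whose value lies beyond the scatter of compound 3; the furthest is compound 2, well beyond the scatter. Compound 2, the one that carries a chloropyridinyl group at the benzylic position, gives the highest number of the set, but it also carries a different substituent on the shared core, so no single-change step can be read from it.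

Compound 4, `Nc1nc(N)c(-c2ccc(NCc3ccncc3)cc2)c(COCc2ccccc2)n1`, follows from compound 3 by one change: pyridin-4-yl in place of 4-cyanophenyl on a saturated chain carbon bound to a nitrogen on an aromatic ring. Among the measured compounds shown here, no measured pair shows this difference in isolation. For the measured compounds named here, the only other pyridine-bearing compound, compound 2, sits at the weak end, but the core differs, so that number can only hint. A moderate weakening in this assay is expected, of the size a 2.6-fold higher number from compound 3 to compound 4 (0.42 log units; beyond the scatter), with the possibility that it stays within the scatter.

For compound 4 the estimate in this assay is 50 nM, with a range from 15 nM to 170 nM.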

Compound 4, half-maximal inhibitory concentration: 86 nM
Estimate against measurement, compound 4: 1.7-fold (0.24 log units) below; low and high end bracket the measured number.
By their numbers in this assay, from the lowest: compound 3; then compounds 1 and 4 (each within the scatter of the next); then compound 2.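

In this assay, among the compounds shown here, this is the first step that can be read from a single change: pyridin-4-yl in place of 4-cyanophenyl on a saturated chain carbon bound to a nitrogen on an aromatic ring gives a 4.5-fold higher number from compound 3 to compound 4 (0.66 log units; beyond the scatter). The group at this position therefore affects the read-out, and with the shared core held constant, the 4-cyanophenyl group is preferred over pyridin-4-yl, although inhibition is still measurable without the nitrile. No measurement on these compounds accounts for the size of this step.

As far as these compounds go, it remains open whether the step goes with the ring nitrogen or with the missing nitrile, and a plain phenyl group at the same place would separate the two. Whether the same change carries over to the core of compound 1 is also unresolved.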